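The source may hold more compounds than are shown below. What is called first, only, known or untested is meant among the compounds shown, and "the series" means these compounds.

Compound 1 `N#Cc1c(Nc2ccccc2)nc(SCc2cn(Cc3ccccc3Cl)nn2)nc1-c1ccccc1`: > 64000 nM in a functional assay on ECa-109 cells (Homo sapiens) for inhibition, read by MTT assay, with a stated time of 72 h (on this read-out higher numbers stand for weaker inhibition and lower numbers for stronger inhibition), a limit of the assay rather than a number.
Compound 2 `Cc1ccc(Nc2nc(SCc3cn(Cc4ccccc4Cl)nn3)nc(-c3ccc(C(C)C)cc3)c2C#N)cc1`: 5080 nM
Compound 3 `COc1ccc(Nc2nc(SCc3cn(Cc4ccccc4Cl)nn3)nc(-c3ccc(C(C)C)cc3)c2C#N)cc1`: 3580 nM

Going by the values given here, compound 2 and compound 3 give the only two numbers, and their gap, a 1.4-fold lower number from compound 2 to compound 3 (0.15 log units; within the scatter), lies within the scatter, so neither stands apart. Compound 4 `COc1cc(-c2nc(SCc3cn(Cc4ccccc4Cl)nn3)nc(Nc3ccc(C)cc3)c2C#N)cc(OC)c1OC` differs from compound 2 by 3,4,5-trimethoxyphenyl in place of 4-isopropylphenyl on an aromatic carbon. Among the compounds with values here, no measured step touches this group: the only measured step, a 1.4-fold lower number from compound 2 to compound 3 (0.15 log units; within the scatter), alters the other aryl ring, while compound 1 differs from compound 2 in two places at once and sits at a limit, (the limit of > 64000 nM in this assay, at which 1 of the 3 values shown sits). The change therefore carries no expectation of a shift beyond the scatter, and compound 4 is estimated at 4500 nM, between 1200 nM and 20000 nM, a step of a 1.1-fold lower number from compound 2 to compound 4 (0.05 log units; within the scatter).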

Compound 4, half-maximal inhibitory concentration: 5850 nM
Compound 4: middle estimate off by 1.3-fold (0.11 log units), on the low side, within the range that was stated.
By their numbers in this assay, from the lowest: compounds 3, 2 and 4 (each within the scatter of the next). At a limit, above all of these: compound 1.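

At this position, ortho to a cyano group, 3,4,5-trimethoxyphenyl in place of 4-isopropylphenyl gives a 1.2-fold higher number from compound 2 to compound 4 (0.06 log units; within the scatter) in this assay. The entering group brings oxygen atoms and hydrogen-bond acceptors that the leaving group lacks, yet the number does not move beyond the scatter. Nothing measured here offers a reason for this.

From the compounds shown here alone, it stays open whether a phenyl ring carrying a carboxylic acid or an amine at this carbon would shift the number beyond the scatter. Going by these compounds, compound 1 differs from compound 2 in two places and its value is a limit, so which difference matters also stays open.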